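Ester side chain: propyl to cyclopropyl on the shared core

This account rests on a few compounds, and the source may have more. Where it says the series, first, only, none or still open, it means among the compounds named here.

compound 1 `CCCCc1nc(C(C)C)c(CC(=O)OCC(F)(F)F)c(=O)n1Cc1ccc(-c2ccccc2-c2noc(=O)[nH]2)cc1` — "not determined" (no result reported)
compound 2 `CCCCc1nc(C(C)C)c(CC(=O)OCCC)c(=O)n1Cc1ccc(-c2ccccc2-c2noc(=O)[nH]2)cc1` — 7.2%
compound 3 `CCCCc1nc(C(C)C)c(CC(=O)OCC(C)C)c(=O)n1Cc1ccc(-c2ccccc2-c2noc(=O)[nH]2)cc1` — 8.8%
compound 4 `CCCCc1nc(C(C)C)c(CC(=O)OC2CC2)c(=O)n1Cc1ccc(-c2ccccc2-c2noc(=O)[nH]2)cc1` — not yet measured

All numbers come from an ADME assay on microsomes from liver (Homo sapiens) for metabolic stability, with a stated time of 30 min; a lower number here means that less of the compound is left, a higher number that more of the compound is left. For the measured compounds named here, compound 2 and compound 3 lie within the scatter of each other: the step of a number 1.6 percentage points higher from compound 2 to compound 3 (within the scatter) is the only measured step in the set. Compound 1 has no result in this assay. Compound 4 differs from compound 2 by cyclopropyl in place of propyl on an oxygen next to a carbonyl group. Going by the values given here, the one step that bears on it, a change on the same ester oxygen, stayed within the scatter, so no step beyond the scatter is expected in this assay. For compound 4 the expected step is a number 1.8 percentage points higher from compound 2 to compound 4 (within the scatter). Compound 4 is thus estimated at 9%, with a range from 3% to 18%.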

Compound 4, percent of the compound remaining: 10.3%
Estimate against measurement, compound 4: 1.3 percentage points below, within the range that was stated.
By their numbers in this assay, from the lowest: compounds 2, 3 and 4 (each within the scatter of the next).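

In this assay, cyclopropyl in place of propyl on the ester oxygen gives a number 3.1 percentage points higher from compound 2 to compound 4 (within the scatter), and cyclopropyl in place of isobutyl gives a number 1.5 percentage points higher from compound 3 to compound 4 (within the scatter). A ring at this position thus joins the chain branching already seen in staying within the scatter, so the three open-chain and ring esters with numbers cannot be told apart. No evidence on the cause accompanies these numbers.

Open, as far as these compounds go, is whether a benzyl or tert-butyl group on this oxygen, or a carboxylic acid in place of the ester, would give a step beyond the scatter.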